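A few compounds are considered here, and "the series" means these few. Any claim that something is new, unique, unknown or untested is made for them only; others in the source may bear on it.

Working notes on the series, followed in a functional assay on MDA-MB-231 cells (Homo sapiens) for inhibition, read by resazurin assay, with a stated time of 72 h; on this read-out lower numbers stand for stronger inhibition and higher numbers for weaker inhibition. Compound 1 `CS(=O)(=O)c1cccc(-c2ccc(-n3cc(-c4ccccc4)nn3)cc2)c1` has a different core from the rest and in this assay returns "not determined" (no result reported). Compound 2 `Clc1ccccc1-c1ccn2ncnc2n1` stands at a limit of this assay, > 100000 nM. Compound 3 `c1ccc(-c2ccn3ncnc3n2)cc1` likewise stands at a limit of this assay, > 100000 nM. For the measured compounds named here, the only measured step, a step that the two limits leave unreadable from compound 2 to compound 3, cannot be sized, since both of its ends rest on (the limit of > 100000 nM in this assay, at which 2 of the 3 values shown sit). Compound 4 `Clc1ccccc1-c1ccccc1-c1ccn2ncnc2n1` differs from compound 3 by 2-chlorophenyl in place of hydrogen on an aromatic carbon. Going by the values given here, no measured step of readable size bears on this change, so the expectation for compound 4 is loose, with a step of an at least 1.6-fold lower number from compound 3 to compound 4 (0.22 log units; that floor lies within the scatter) expected to leave it weak. Compound 4 is estimated at 60000 nM, with a range from 10000 nM to 300000 nM.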

Compound 4, half-maximal inhibitory concentration: > 100000 nM
Compound 4: a limit, no number (the forecaster's own chance of this, stated with the estimate: 55%); middle value at least 1.6-fold (0.22 log units) from the limit.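

Compound 4 rests at the same limit as compound 2 and compound 3, so neither of its steps from those two compounds can be read: the limit of > 100000 nM in this assay, at which 3 of the 4 values shown sit. The compounds shown leave open whether any change on the shared core yields a number rather than a limit.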